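The compounds below may be only part of what the source reports. "The series", "measured", "known", "first", "only" and "open" are said of these compounds alone.

The series shares one core, varied at the ring on the propyl chain and elsewhere in the molecule. Going by the values given here, compound 1 `COc1cc2c(Nc3nc4ccc(C(=O)Nc5c(C)cc(C)cc5C)cc4s3)ncnc2cc1OCCCN1CCC(C)CC1` is the only member with a number rather than a limit: in a functional assay on DLD-1 cells (Homo sapiens) for cytotoxicity, read by WST assay, with a stated time of 72 h (on this read-out higher numbers stand for weaker inhibition and lower numbers for stronger inhibition), compound 1 gives 7000 nM. Compound 2 `COc1cc2c(Nc3nc4ccc(C(=O)Nc5c(C)cccc5C)cc4s3)ncnc2cc1OCCCN1CCCCC1` is reported only as a limit in this assay, where compound 2 gives > 100000 nM. Compound 3 `COc1cc2c(Nc3nc4ccc(C(=O)Nc5c(C)cccc5C)cc4s3)ncnc2cc1OCCCN1CCCCC1C` likewise reaches only a limit in this assay, compound 3 giving > 100000 nM. The step that the two limits leave unreadable from compound 2 to compound 3 cannot be read because both of its ends sit at the limit of > 100000 nM in this assay, at which 2 of the 3 values shown sit. Compound 3 therefore stands at the weak end of the numbers shown, with no readable step attached to it.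

Compound 4 `COc1cc2c(Nc3nc4ccc(C(=O)Nc5c(C)cccc5C)cc4s3)ncnc2cc1OCCCN1CCC(C)CC1` differs from compound 3 by 4-methylpiperidin-1-yl in place of 2-methylpiperidin-1-yl on a saturated chain carbon, three bonds along the chain from an oxygen on an aromatic ring. Among the compounds with values here, no measured step bears directly on this change; the only step that touches the ring on the chain, from compound 2 to compound 3, is unreadable. Compound 1 also carries the 4-methylpiperidin-1-yl group but differs from compound 4 elsewhere, so compound 1 at 7000 nM is only a loose reference. Compound 4 is therefore expected to stay near the limit, the step of an at least 1.6-fold lower number from compound 3 to compound 4 (0.22 log units; that floor lies within the scatter) being an estimate the data cannot check. The estimate for compound 4 in this assay is 60000 nM, with a range from 10000 nM to 300000 nM.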

Compound 4, half-maximal inhibitory concentration: > 100000 nM
Compound 4: a limit, no number; the forecaster's own chance of this, stated with the estimate: 60%; middle value at least 1.6-fold (0.22 log units) from the limit.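

Compound 4 ends at a limit of this assay, not at a number, so the 4-methylpiperidin-1-yl group on the propyl chain does not by itself give a measurable value when the shared core lacks the extra aromatic methyl of compound 1. The steps that link compound 4 to compound 2 and compound 3 cannot be read because both ends of each step sit at one value: the limit of > 100000 nM in this assay, at which 3 of the 4 values shown sit. The comparison with compound 1 gives the first readable step in the series: hydrogen in place of methyl on an aromatic carbon, with the 4-methylpiperidin-1-yl group held constant, produces an at least 14-fold higher number from compound 1 to compound 4 (1.15 log units; beyond the scatter), so this single change on the aromatic carbon matters in a way that the changes on the saturated ring have not been shown to.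

From the compounds shown here alone, it remains open whether the same aromatic methyl would also give a number alongside the 2-methylpiperidin-1-yl group or the unsubstituted piperidine of compound 2. Also open, going by these compounds, is how chlorine or methoxy on that aromatic carbon, or a morpholine ring on the propyl chain, would behave in this assay.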